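Para-chloro on the phenyl of compound 1

A few compounds are considered here, and "the series" means these few. Any claim that something is new, unique, unknown or untested is made for them only; others in the source may bear on it.

Compound 1 `c1ccc(-c2cn3ccnc3c(-c3ccc4ncn(C5CCCCC5)c4c3)n2)cc1` has the higher of the two measured numbers in this series: in a functional assay on HCT-116 cells (Homo sapiens) for inhibition, read by sulforhodamine B assay, with a stated time of 48 h, tested at 10 uM (on this read-out higher numbers stand for more inhibition at the one concentration tested (going by the name of the read-out) and lower numbers for less inhibition), compound 1 gives 59.5%, the highest of the two numbers, while compound 2 `c1cn2cc(-c3ccsc3)nc(-c3ccc4ncn(C5CCCCC5)c4c3)c2n1` gives 13.4%. Among the measured compounds shown here, the single measured step, a number 46.1 percentage points lower from compound 1 to compound 2 (beyond the scatter), swaps the whole aromatic ring and says nothing about a substituent added to the phenyl itself.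

Compound 3 `Clc1ccc(-c2cn3ccnc3c(-c3ccc4ncn(C5CCCCC5)c4c3)n2)cc1` differs from compound 1 by chloro in place of hydrogen on an aromatic carbon. For the measured compounds named here, no measured step bears on this change; the ring that carried the large drop in compound 2 is kept here. The expectation is therefore a step no larger than the scatter, a number 0.5 percentage points higher from compound 1 to compound 3 (within the scatter), with the direction open. For compound 3 the estimate in this assay is 60%, within 35% to 80%.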

Compound 3, a percentage reported as inhibition, at one concentration (the size of the read-out at that concentration, not a potency): 7.34%
Compound 3: the middle estimate sits 52.7 percentage points above what was measured, and the stated range ends above it.
By their numbers in this assay, from the lowest: compounds 3 and 2 (each within the scatter of the next); then compound 1.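

Chloro in place of hydrogen on the phenyl, para to a large group, gives a number 52.2 percentage points lower from compound 1 to compound 3 (beyond the scatter) in this assay, so a change of one heavy atom at this position also produces a large step, without any exchange of the ring. With a number 6.1 percentage points lower from compound 2 to compound 3 (within the scatter), 4-chlorophenyl and thiophen-3-yl cannot be told apart in this read-out, and among the three groups only the unsubstituted phenyl of compound 1 stands apart. Nothing available accounts for the loss on adding chloro.

Going by these compounds, it remains open whether this loss is specific to chloro or extends to other groups on the same carbon, such as fluoro, methoxy or an amine. The compounds shown also leave open whether the phenyl accepts any substituent at its other carbons while keeping the number seen for compound 1.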